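A few compounds are considered here, and "the series" means these few. Any claim that something is new, unique, unknown or untested is made for them only; others in the source may bear on it.

Measured compounds:
compound 1, `Cc1ccc(Nc2nc(Cl)nc3c2ncn3Cc2ccc(C(=O)Nc3ccccc3N)cc2)cc1`, 76.2%
compound 2, `Nc1ccccc1NC(=O)c1ccc(Cn2cnc3c(NCc4ccccc4)nc(Cl)nc32)cc1`, 7.55%

In a functional assay on HepG2 cells (Homo sapiens) for antiproliferative activity, read by CCK-8 assay, with a stated time of 72 h, tested at 2 uM (on this read-out lower numbers stand for a weaker effect and higher numbers for a stronger effect at the one concentration tested), compound 2 gives 7.55%, the lower of the two numbers; its nearest neighbour is compound 1, which gives 76.2%. For the measured compounds named here, the only step between the measured compounds is a number 68.7 percentage points lower from compound 1 to compound 2 (beyond the scatter), a large fall that came with the change from 4-methylphenyl to benzyl on the nitrogen on the aromatic ring.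

Compound 3, `Nc1ccccc1NC(=O)c1ccc(Cn2cnc3c(Nc4ccc(-c5ccccn5)cc4)nc(Cl)nc32)cc1`, differs from compound 2 in one place: 4-(pyridin-2-yl)phenyl in place of benzyl on a nitrogen on an aromatic ring. This change runs back in the direction of compound 1, since it again puts a six-membered aromatic ring of carbon only directly on the nitrogen, as in compound 1, rather than benzyl. The step from compound 1 to compound 2 is therefore the one that bears on it, and it was large. A step of similar size in the opposite direction, upward in this assay, is expected from compound 2 to compound 3, that is a number 57.5 percentage points higher from compound 2 to compound 3 (beyond the scatter). Going by the values given here, with only one such step to lean on, the range is kept wide. Compound 3 is thus estimated at 65%, between 35% and 90%.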

Compound 3, a percentage reported as inhibition, at one concentration (the size of the read-out at that concentration, not a potency): 11.5%
The estimate for compound 3 lay 53.5 percentage points above the measured number; measured number below the stated range.
By their numbers in this assay, from the lowest: compounds 2 and 3 (each within the scatter of the next); then compound 1.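

In this assay the exchange of benzyl for 4-(pyridin-2-yl)phenyl on the nitrogen gives a number 4 percentage points higher from compound 2 to compound 3 (within the scatter) and so leaves the effect in the range of compound 2, even though a six-membered aromatic ring of carbon only again sits directly on that nitrogen. Having that ring on the nitrogen is therefore not enough on its own, and what the ring carries also counts: pyridin-2-yl in place of the methyl of compound 1 gives a number 64.7 percentage points lower from compound 1 to compound 3 (beyond the scatter) and thus a large fall from a change made on an aromatic carbon, away from the nitrogen itself. No measurement available here accounts for this fall, so the result stands as an observation without an explanation.

The compounds shown leave open whether the loss goes with the added ring as a whole or with its ring nitrogen, a question that a plain phenyl in place of pyridin-2-yl would address. They also leave open how far that place tolerates other groups, such as a methoxy group, a chlorine atom or an amine in place of the methyl of compound 1.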